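The source may hold more compounds than are shown below. What is called first, only, known or untested is meant among the compounds shown, and "the series" means these compounds.

In a toxicity assay on L02 cells (Homo sapiens) for cytotoxicity, read by MTT assay, with a stated time of 72 h (a lower number here means a stronger inhibitor, a higher number a weaker inhibitor), compound 3 `CN(C)CCCCn1c2c(c3ccccc31)C(=O)c1c[n+]([O-])c3ccccc3c1C2=O` gives 300 nM. Compound 1 `CN1CCN(CCCn2c3c(c4ccccc42)C(=O)c2c[n+]([O-])c4ccccc4c2C3=O)CC1` gives 230 nM, and a 1.3-fold higher number from compound 1 to compound 3 (0.12 log units; within the scatter) leaves the two level. Compound 2 `O=C1c2c[n+]([O-])c3ccccc3c2C(=O)c2c1c1ccccc1n2CCN1CCCCC1` gives 1050 nM, the highest number of the three, and a 3.5-fold lower number from compound 2 to compound 3 (0.54 log units; beyond the scatter) marks the gap. The next change, to compound 4 `O=C1c2c[n+]([O-])c3ccccc3c2C(=O)c2[nH]c3ccccc3c21`, is hydrogen in place of 4-(dimethylamino)butyl on an aromatic nitrogen. Among the compounds with values here, no measured step removes the whole chain. The closest guides are a 4.6-fold higher number from compound 1 to compound 2 (0.66 log units; beyond the scatter) and that same modest gap, while the step within the scatter shows that chain changes need not move the number. A modest move towards a higher number is therefore expected, with weak support. The expected step is a 3.0-fold higher number from compound 3 to compound 4 (0.48 log units; beyond the scatter). Compound 4 is estimated at 900 nM, with an expected range of 200 nM to 4000 nM.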

Compound 4, half-maximal inhibitory concentration: 400 nM
Compound 4: middle estimate off by 2.3-fold (0.35 log units), on the high side; the range from low to high includes it.
By their numbers in this assay, from the lowest: compounds 1, 3 and 4 (each within the scatter of the next); then compound 2.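

On the aromatic nitrogen, hydrogen stays level with two of the chains in this assay, with a 1.3-fold higher number from compound 3 to compound 4 (0.12 log units; within the scatter) and a 1.7-fold higher number from compound 1 to compound 4 (0.24 log units; within the scatter), so neither 4-(dimethylamino)butyl nor 3-(4-methylpiperazin-1-yl)propyl moves the number from that of hydrogen. Only 2-(piperidin-1-yl)ethyl stands apart, with a 2.6-fold lower number from compound 2 to compound 4 (0.42 log units; beyond the scatter) on its removal, so one chain of the three carries a higher number beyond the scatter. Nothing measured accounts for that difference between the chains.

Open, from the compounds shown here alone, is whether a methyl group or a chain ending in a carboxylic acid on this nitrogen would also stay level with hydrogen.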